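Adding a nitro group to a benzamide-bearing triazole

A few compounds are considered here, and "the series" means these few. Any claim that something is new, unique, unknown or untested is made for them only; others in the source may bear on it.

Of the compounds shown here, three have been tested in a functional assay on the whole organism (strain albino) for inhibition, with Rattus norvegicus as the target, read by paw edema, with stated times of 30 min and 2 h, at a dose of 5 mg/kg by the oral route; on this read-out higher numbers stand for more inhibition at the one dose given (going by the name of the read-out) and lower numbers for less inhibition. Compound 1, `Nc1nc(CC(=O)O)n[nH]1`, gives 29.5% in this assay. Compound 2, `CCOC(=O)Cc1nc(N)n(C(=O)c2ccc(Br)cc2)n1`, gives 43%. Compound 3, `CCOC(=O)Cc1n[nH]c(NC(=O)c2ccccc2)n1`, gives 36.2%. The number for compound 3 lies between the other two, yet its distances to compound 1 and to compound 2 both fall within the usual scatter of repeated measurements, so the three compounds cannot be told apart on these numbers.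

Compound 4, `CCOC(=O)Cc1n[nH]c(NC(=O)c2ccc([N+](=O)[O-])cc2)n1`, has not been measured. It differs from compound 3 by a single change: nitro in place of hydrogen on an aromatic carbon. Among the measured compounds shown here, no measured pair shows what such a change does in this assay, and the three numbers at hand give no trend to lean on. The expectation is therefore that the step of a number 1.8 percentage points higher from compound 3 to compound 4 (within the scatter) will be small, in no particular direction, and not beyond the scatter. On that basis compound 4 is estimated at 38%, with a plausible range from 25% to 52%.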

Compound 4, a percentage reported as inhibition, in the whole organism at one dose (the size of the read-out at that dose, not a potency): 42.1%
Compound 4: middle estimate off by 4.1 percentage points, on the low side; low and high end bracket the measured number.
By their numbers in this assay, from the lowest: compounds 1, 3, 4 and 2 (each within the scatter of the next, the first and the last beyond it).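

In this assay, among the compounds shown here, the pair of compound 3 and compound 4 is the first to differ in one place only, and nitro in place of hydrogen on an aromatic carbon, para to a large group, gives a number 5.9 percentage points higher from compound 3 to compound 4 (within the scatter). So this position of the benzamide ring can carry a nitro group, with its three heavy atoms, without the read-out moving beyond the usual scatter of repeated measurements, though this rests on a single pair at a single dose. Nothing here bears on why the step has this size.

On these data alone, what a methoxy group or a trifluoromethyl group would do at this same place stays open. Also open, as far as these compounds go, is whether nitro would give a step beyond the scatter at another dose or elsewhere on the ring.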